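The compounds below may be only part of what the source reports. "The series", "measured", "known", "first", "only" and "open" are said of these compounds alone.

Measured in a functional assay on HepG2 cells (Homo sapiens) for cytotoxicity, read by MTT assay, with a stated time of 24 h; a lower number here means a stronger inhibitor, a higher number a weaker inhibitor:
Compound 1 `CN1C/C(=C\c2cccc([N+](=O)[O-])c2)C(=O)/C(=C/c2ccc(Cl)cc2Cl)C1`: 4800 nM
Compound 2 `CN1C/C(=C\c2ccc(Cl)cc2)C(=O)/C(=C/c2ccc(C#N)cc2)C1`: 5950 nM

In this assay, compound 2 gives 5950 nM, which lies within the usual scatter of the value for compound 1, so the two cannot be told apart. Compound 3 `CN1C/C(=C\c2ccc(C#N)cc2)C(=O)/C(=C/c2ccc(Cl)cc2Cl)C1` departs from compound 2 in one place: chloro in place of hydrogen on an aromatic carbon. Here 4-chlorophenyl becomes 2,4-dichlorophenyl. Within the data shown here, no measured pair isolates this change. Among the measured compounds shown here, the only guide is compound 1, which carries the same 2,4-dichlorophenyl group and gives 4800 nM. No step beyond the scatter is therefore expected in this assay, in either direction. The expected change is a 1.2-fold lower number from compound 2 to compound 3 (0.09 log units; within the scatter). For compound 3 the estimated value is 4800 nM, with an expected range from 1900 nM to 12000 nM.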

Compound 3, half-maximal inhibitory concentration: 6250 nM
Estimate against measurement, compound 3: 1.3-fold (0.11 log units) below; measured number inside the range.
By their numbers in this assay, from the lowest: compounds 1, 2 and 3 (each within the scatter of the next).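

In this assay the chloro group entering on an aromatic carbon, ortho to a large group and meta to a chloro group, gives a 1.1-fold higher number from compound 2 to compound 3 (0.02 log units; within the scatter) and leaves compound 2 and compound 3 indistinguishable. Among these compounds, the other comparison, 4-cyanophenyl in place of 3-nitrophenyl on the double-bonded chain carbon, gives a 1.3-fold higher number from compound 1 to compound 3 (0.11 log units; within the scatter) and so also separates no pair of compounds. No measurement shown here accounts for either result. The compounds shown leave open whether a different group at this place, such as an amine or a methoxy group, would produce a step beyond the scatter. On these data alone, all three also share the same core with its methyl group, so the effect of a longer chain there remains unknown.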